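This account rests on a few compounds, and the source may have more. Where it says the series, first, only, none or still open, it means among the compounds named here.

Measured in a functional assay on MDA-MB-231 cells (Homo sapiens) for antiproliferative activity, read by sulforhodamine B assay, with a stated time of 48 h; on this read-out higher numbers stand for weaker inhibition and lower numbers for stronger inhibition:
- compound 1 `COc1cc(OC)c2sc(-c3ccc(N/C=C\C(=O)c4ccc(OC)c(O)c4)c(C)c3)nc2c1`: 3100 nM
- compound 2 `COc1cc(OC)c2sc(-c3ccc(N/C=C\C(=O)c4cc(OC)c(OC)c([N+](=O)[O-])c4)c(C)c3)nc2c1`: 7400 nM

Of the two, compound 2 stands at the higher number, 7400 nM, and so at the weaker inhibition. Compound 1, at 3100 nM, lies lower by more than the usual scatter. The two compounds differ in more than one place, so their gap cannot be tied to any single group.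

Compound 3 `COc1cc(OC)c2sc(-c3ccc(N/C=C\C(=O)c4cc(OC)c(OC)c(OC)c4)c(C)c3)nc2c1` has yet to be measured. It differs from compound 2 in one place, with methoxy in place of nitro on an aromatic carbon. Among the measured compounds shown here, no single-change step among the measured compounds gauges this swap, so the expectation is loose. It rests on compound 1, which carries no nitro group and gives 3100 nM. A modest shift towards stronger inhibition in this assay is therefore expected, and the estimated step is a 2.5-fold lower number from compound 2 to compound 3 (0.39 log units; beyond the scatter), which may prove little larger than the scatter. The estimated value for compound 3 is 3000 nM, with an expected range from 800 nM to 9000 nM.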

Compound 3, half-maximal inhibitory concentration: 13800 nM
For compound 3 the middle estimate is 4.6-fold (0.66 log units) below the measured one; the measured number lies above the stated range.
By their numbers in this assay, from the lowest: compound 1; then compounds 2 and 3 (each within the scatter of the next).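

In this assay, methoxy in place of nitro on an aromatic carbon, ortho to a methoxy group, gives a 1.9-fold higher number from compound 2 to compound 3 (0.27 log units; within the scatter) and so leaves the read-out at this position not distinguishable from that of the nitro compound. Losing the nitro group therefore does not by itself bring the number towards that of compound 1, and the larger difference appears in the other single change, where 3,4,5-trimethoxyphenyl stands in place of 3-hydroxy-4-methoxyphenyl on a carbonyl carbon, with a 4.5-fold higher number from compound 1 to compound 3 (0.65 log units; beyond the scatter) in this comparison. No measurement at hand accounts for either step.

The compounds shown leave open whether the loss of the hydroxy group or the presence of the added methoxy groups underlies the step between compound 1 and compound 3, since that change alters both at once. They also leave open how an amine or a chlorine atom at the position held by nitro in compound 2 and by methoxy in compound 3 would read in this assay against these two groups.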